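The compounds below may be only part of what the source reports. "The series", "measured", "known", "first", "only" and "open" are said of these compounds alone.

Compound 1 `Oc1cc(C(F)(F)F)ccc1-c1nc(-c2ccccc2O)n(-c2ccc(Cl)cc2)n1`: 96.1%
Compound 2 `Oc1cc(C(F)(F)F)ccc1-c1nc(-c2ccccc2O)n(-c2cccc(F)c2)n1`: 98.3%

Both compounds were tested in a functional assay on PC-12 cells (Rattus norvegicus) for cytotoxicity, read by MTT assay, with stated times of 2 h and 24 h, tested at 10 uM; on this read-out lower numbers stand for a weaker effect and higher numbers for a stronger effect at the one concentration tested. Within the data shown here, compound 1 stands lowest of the two numbers, the only other number lying a number 2.2 percentage points higher from compound 1 to compound 2 (within the scatter). Compound 3 `COc1cccc(-n2nc(-c3ccc(C(F)(F)F)cc3O)nc2-c2ccccc2O)c1` differs from compound 1 by 3-methoxyphenyl in place of 4-chlorophenyl on an aromatic nitrogen. Among the measured compounds shown here, the one measured step that bears on this change is a number 2.2 percentage points higher from compound 1 to compound 2 (within the scatter), which likewise exchanges the group on the aromatic nitrogen and stays within the scatter. From that single comparison, no step beyond the scatter is expected. Compound 3 is therefore expected to give 95%, within 80% to 100%. The expected step is a number 1.1 percentage points lower from compound 1 to compound 3 (within the scatter).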

Compound 3, a percentage reported as activity, at one concentration (the size of the read-out at that concentration, not a potency): 106%
Compound 3: the middle estimate sits 11 percentage points below what was measured, outside the stated range (above it).
By their numbers in this assay, from the lowest: compounds 1, 2 and 3 (each within the scatter of the next).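

Across this change the read-out in this assay does not leave the scatter: 3-methoxyphenyl in place of 4-chlorophenyl on the aromatic nitrogen gives a number 9.9 percentage points higher from compound 1 to compound 3 (within the scatter) and methoxy in place of fluoro on the aromatic carbon gives a number 7.7 percentage points higher from compound 2 to compound 3 (within the scatter) and so neither exchange separates the compounds. The aromatic nitrogen thus carries a group with a hydrogen-bond acceptor and no step beyond the scatter appears. No measurement offered here explains these numbers.

On these data alone, whether any group at this position moves the number beyond the scatter remains open. An amine or a carboxylic acid on that phenyl ring, or a longer chain in place of methoxy, would test this.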